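Removing a Fluoro Group from a Biphenyl Urea

The compounds below may be only part of what the source reports. "The series", "measured", "known", "first", "only" and "open" are said of these compounds alone.

Compound 1 `Cc1ccc(CN2CCC(CCN(Cc3ccc(-c4ccccc4)cc3)C(=O)NC(C)(C)CO)CC2)cc1`: 6.2 in an in vitro functional assay on HEK293 cells for antagonist activity at melanin-concentrating hormone receptor 1 (Homo sapiens), read by GTPgammaS binding, with a stated time of 45 min; on this read-out higher numbers stand for higher potency (the scale is a negative logarithm) and lower numbers for lower potency
Compound 2 `CCC(CO)(CO)NC(=O)N(CCC1CCN(Cc2ccc(C)cc2)CC1)Cc1ccc(-c2ccc(F)cc2)cc1`: 6.54 in this assay

Among the measured compounds shown here, compound 2 stands highest of the two numbers measured so far; its nearest neighbour, compound 1, lies lower by a gap beyond the usual scatter. The two differ at more than one place, so their gap cannot be assigned to any single change.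

Compound 3 `CCC(CO)(CO)NC(=O)N(CCC1CCN(Cc2ccc(C)cc2)CC1)Cc1ccc(-c2ccccc2)cc1` arises from compound 2 by one change: hydrogen in place of fluoro on an aromatic carbon. For the measured compounds named here, no pair of measured compounds isolates this change, so the expectation rests on compound 2 alone. A small loss is anticipated, of a size that stays within the scatter. The expected step of a number 0.24 log units lower from compound 2 to compound 3 (within the scatter) is thus a modest downward move. Compound 3 is therefore estimated at 6.3 in this assay, with a likely range from 5.9 to 6.7.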

Compound 3, negative logarithm of the antagonist equilibrium constant: 6.84
The estimate for compound 3 lay 0.54 log units below the measured number; measured number outside the range, above it.
By their numbers in this assay, from the lowest: compound 1; then compounds 2 and 3 (each within the scatter of the next).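

In this assay the 4-fluorophenyl to phenyl change gives a number 0.30 log units higher from compound 2 to compound 3 (within the scatter), so on this aromatic carbon, para to a large group, hydrogen and fluoro cannot be told apart. Among the compounds shown here, compound 3 also provides the first comparison at the amide-type nitrogen: 1,1-bis(hydroxymethyl)propyl in place of 1-(hydroxymethyl)-1-methylethyl gives a number 0.64 log units higher from compound 1 to compound 3 (beyond the scatter), a step that clears the scatter and makes this the one change here with a readable effect on the number. No measurement shown bears on the reason for either step.

The compounds shown leave open how a chloro, methoxy or nitrile group would read at the aromatic position. They also leave open how a 1,1-dimethylethyl group or a longer chain would read on the amide-type nitrogen.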